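This account rests on a few compounds, and the source may have more. Where it says the series, first, only, none or still open, it means among the compounds named here.

Compounds measured so far:
compound 1 `O=C(O)CCCSCCN1C(=O)CC[C@@H]1/C=C/[C@@H](O)Cc1cccc(-c2ccc3[nH]ccc3c2)c1` – > 10000 nM
compound 2 `O=C(O)CCCSCCN1C(=O)CC[C@@H]1/C=C/[C@@H](O)Cc1cccc(OCc2ccncc2)c1` – > 10000 nM
compound 3 `O=C(O)c1csc(SCCN2C(=O)CC[C@@H]2/C=C/[C@@H](O)Cc2cccc(-c3ccccc3)c2)n1` – 4200 nM

In an assay on CHO cells for displacement of a labelled ligand from prostaglandin E2 receptor EP1 subtype (Mus musculus), read by scintillation counting, with a stated time of 20 min (a higher number here means a weaker inhibitor, a lower number a stronger inhibitor), compound 1 gives only a limit, > 10000 nM. Compound 2 likewise gives only a limit in this assay, > 10000 nM. The step from these two, a step that the two limits leave unreadable from compound 1 to compound 2, therefore cannot be read. Within the data shown here, compound 3 is the only compound with a number in this assay, 4200 nM; the other two values rest at the limit of > 10000 nM in this assay, at which 2 of the 3 values shown sit.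

Compound 4 `O=C(O)c1csc(SCCN2C(=O)CC[C@@H]2/C=C/[C@@H](O)Cc2cccc(-c3nc4ccccc4o3)c2)n1` differs from compound 3 in one place: 1,3-benzoxazol-2-yl in place of phenyl on an aromatic carbon. Among the measured compounds shown here, no measured step bears on this change, since the only step available, from compound 1 to compound 2, is hidden by the limits, and the aryl group that changes in it is of another kind. With no evidence on the size or direction of such a change, the expectation for compound 4 is that its value stays within the scatter of compound 3, so that the step of a 1.2-fold lower number from compound 3 to compound 4 (0.08 log units; within the scatter) is expected to be small. Compound 4 is thus estimated at 3500 nM, with a range from 900 nM to 12000 nM.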

Compound 4, inhibition constant: > 10000 nM
Compound 4 gave a limit, no number; the forecaster's own chance of this, stated with the estimate: 30%; middle value at least 2.8-fold (0.45 log units) from the limit.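

The step from phenyl to 1,3-benzoxazol-2-yl, at this place meta to a large group, is the first readable change among the compounds shown: an at least 2.3-fold higher number from compound 3 to compound 4 (0.37 log units; beyond the scatter). It shows that in this assay this position does not tolerate every aromatic group equally on the core of compound 3, and that the added five-membered ring with its hetero atoms comes with weaker inhibition than phenyl. Compound 4 gives only a limit, so the step has a lower bound but no full size, and phenyl remains the only group here with a number, the rest of the series sitting at the same edge: the limit of > 10000 nM in this assay, at which 3 of the 4 values shown sit.

From the compounds shown here alone, whether the loss follows the fused bicyclic group as a whole or its ring nitrogen and oxygen stays open, and a benzofuran-2-yl or a plain oxazol-2-yl at this carbon would separate the two. Going by these compounds, how a smaller pyridin-2-yl or a simple methoxy would read on this core also remains open.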